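The compounds below may be only part of what the source reports. "The series", "measured", "known", "first", "only" and "open" are said of these compounds alone.

Measured so far in an ADME assay on S9 fraction from liver (Rattus norvegicus) for metabolic stability, read by LC-MS, using NADPH, with a stated time of 30 min; on this read-out higher numbers stand for a more stable compound and lower numbers for a less stable compound:
Compound 1 `CCCCCCCCc1ccc(OCC(=O)Cn2ncnn2)cc1`: < 5%, which is a limit of the assay rather than a number.
Compound 2 `CCCCCCCCc1ccc(OCC(=O)Cn2nnc(-c3ccccc3Cl)n2)cc1`: 28%.
Compound 3 `CCCCCCCCc1ccc(OCC(=O)Cn2nnc(-c3ccc(S(=O)(=O)N(C)C)cc3)n2)cc1`: 65%.

Compound 1 therefore stands at the floor of the assay (the limit of < 5% in this assay, at which 1 of the 3 values shown sits), so only a bound, not a value, is known for it. Compound 4 `CCCCCCCCc1ccc(OCC(=O)Cn2nnc(-c3ccncc3)n2)cc1` differs from it in one place: pyridin-4-yl in place of hydrogen on an aromatic carbon. Among the compounds with values here, two measured steps bear on this, each replacing the same hydrogen with a larger group: a number at least 23 percentage points higher from compound 1 to compound 2 (beyond the scatter) and a number at least 60 percentage points higher from compound 1 to compound 3 (beyond the scatter). Both went up beyond the scatter, the larger rise coming with the 4-(dimethylsulfamoyl)phenyl group. A rise is thus expected for compound 4 too, a number at least 35 percentage points higher from compound 1 to compound 4 (beyond the scatter). The estimate for compound 4 is 40%, with a range from 15% to 70%.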

Compound 4, percent of the compound remaining: < 5%
Compound 4 ended at the assay's limit (the forecaster's own chance of this, stated with the estimate: 10%); middle value at least 35 percentage points from the limit.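

A six-membered aromatic ring on this carbon is not enough on its own to raise the number, and the group chosen matters: there is a number at least 60 percentage points lower from compound 3 to compound 4 (beyond the scatter) and a number at least 23 percentage points lower from compound 2 to compound 4 (beyond the scatter). In this assay compound 4 sits at a limit rather than a number, and its step from compound 1 cannot be read: the limit of < 5% in this assay, at which 2 of the 4 values shown sit.

The compounds shown leave open whether the ring nitrogen of pyridin-4-yl or the lack of a further substituent on that ring sets compound 4 apart from compound 2 and compound 3. A plain phenyl group on this carbon would help separate the two.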